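The compounds below may be only part of what the source reports. "The series", "measured", "known", "first", "only" and "open" are said of these compounds alone.

Measured so far in a functional assay on RPMI-8226 cells (Homo sapiens) for cytotoxicity, read by sulforhodamine B assay, with a stated time of 48 h, tested at 0.1 uM; a lower number here means a stronger effect, a higher number a weaker effect of the compound at the concentration tested:
compound 1 `COc1cc(-c2cc(/C=C/C(=O)c3ccc(N)cc3)[nH]n2)cc(OC)c1OC`: compound 1 gives 97%
compound 2 `COc1ccc(-c2cc(/C=C/C(=O)c3ccc(N)cc3)[nH]n2)cc1OC`: compound 2 gives 96%
compound 3 `COc1cc(C(=O)/C=C/c2cc(-c3cc(OC)c(OC)c(OC)c3)n[nH]2)cc(OC)c1OC`: compound 3 gives 83%

Compound 1 and compound 2 share one core; compound 2 differs from compound 1 by hydrogen in place of methoxy on an aromatic carbon. In this assay this gave a number 1 percentage points lower from compound 1 to compound 2 (within the scatter). Compound 3 carries a different core; the difference between the two cores is not broken down here. Compound 3 gives a lower number than compound 1 and than compound 2, both gaps beyond the usual scatter.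

Compound 4 `COc1ccc(-c2cc(/C=C/C(=O)c3cc(OC)c(OC)c(OC)c3)[nH]n2)cc1OC` is not yet measured. It differs from compound 3 by hydrogen in place of methoxy on an aromatic carbon. The place is described in the same words as for compound 1 to compound 2, so this is the same change carried onto the core of compound 3. Because that change gave a number 1 percentage points lower from compound 1 to compound 2 (within the scatter), the expected step is a number 1 percentage points lower from compound 3 to compound 4 (within the scatter), though this rests on one measured pair and the other core need not repeat it. Compound 4 is expected to give about 82% in this assay, with a likely range from 70% to 94%.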

Compound 4, a percentage reported as activity, at one concentration (the size of the read-out at that concentration, not a potency): 85%
The estimate for compound 4 lay 3 percentage points below the measured number; the measured number falls inside the stated range.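

In this assay, hydrogen in place of methoxy on an aromatic carbon of the core of compound 3 gives a number 2 percentage points higher from compound 3 to compound 4 (within the scatter). Set beside the earlier step, the same change shows no difference between the two cores: the same change on two cores in this assay, a number 1 percentage points lower (within the scatter) from compound 1 to compound 2 and a number 2 percentage points higher (within the scatter) from compound 3 to compound 4, 3 percentage points apart, within the scatter of two such steps. Across these two pairs, the swap of methoxy for hydrogen therefore reads the same on both cores, but neither step stands out from the scatter, so the series shows no measurable effect being carried over, and two pairs at a single concentration do not show that a larger effect would transfer or that the change would be equally silent on other cores.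

Still open, going by these compounds, is whether a hydroxyl group or a chlorine atom at this place on the aromatic ring would give a step beyond the scatter on either core. Also open, on these data alone, is whether the two steps would still match at other concentrations, since a read-out at one concentration is not a potency.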